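Swapping double-bond geometry from compound 2 to compound 3

The source may report more compounds than this note shows. Statements on the series, on what has been measured and on what is new or still open speak of the compounds shown alone.

In a functional assay on M12 cells (Homo sapiens) for antiproliferative activity, read by WST assay, with a stated time of 72 h (a lower number here means that less compound is needed, a higher number that more compound is needed for the effect), compound 1 `CCCCCCCC/C=C/c1c(C)c(/C=C/CCCCCCCC)c2[n+](c1C)CCC2` gives 2.2 uM and compound 2 `CCCCCCCC/C=C\c1c(C)c(/C=C/CCCCCCCC)c(C)[n+]2c1CCC2` gives 2.4 uM on the same read-out, so compound 2 stands level with compound 1 within the scatter and the pair cannot be separated. Compound 3 `CCCCCCCC/C=C\c1c(C)c(/C=C/CCCCCCCC)c2[n+](c1C)CCC2` is the next isomer to be read. Relative to compound 2 the change is the two compounds have the same atoms and bonds and differ only in configuration as drawn: 2 of 2 stereo elements differ; a double bond is drawn E in compound 2 and Z in compound 3; a double bond is drawn Z in compound 2 and E in compound 3 and nothing leaves or enters: a double bond is drawn E in compound 2 and Z in compound 3, and a double bond is drawn Z in compound 2 and E in compound 3. Going by the values given here, one measured step bears on this, a 1.1-fold higher number from compound 1 to compound 2 (0.04 log units; within the scatter) in that pair, and it serves as a precedent because of the fact that compounds 1 and 2 differ only in the configuration as drawn and the same kind of change here. Among the compounds with values here, that step altered one double bond, whereas here both are altered, and no measured step covers such a double swap. No change beyond the scatter is therefore expected in this assay and no direction is favoured. The expected move is a 1.0-fold lower number from compound 2 to compound 3 (0.02 log units; within the scatter) on this estimate. Compound 3 is estimated at 2.3 uM with an expected range from 1.2 uM to 4.5 uM for the measurement.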

Compound 3, concentration for half-maximal effect: 2.2 uM
Estimate against measurement, compound 3: 1.0-fold (0.02 log units) above; measured number inside the range.
By their numbers in this assay, from the lowest: compounds 1, 3 and 2 (each within the scatter of the next).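

In this assay, going by these compounds alone, the change of both double bonds at once gives a 1.1-fold lower number from compound 2 to compound 3 (0.04 log units; within the scatter) and the change of a single double bond gives no change at the digits printed from compound 1 to compound 3 (within the scatter) in the same series, so a double swap now has a reading of its own beside the single swaps. The three geometric isomers thus stand within the scatter of one another in this assay, and at this level of resolution the geometry of neither double bond separates them, whether one is altered or both. The comparison isolates geometry and nothing else, with no atom leaving or entering: the fact that compounds 2 and 3 differ only in the configuration as drawn.

Open, on these data alone, is whether anything other than double-bond geometry moves the number, since all three compounds carry the same atoms and bonds on the same core. A fully saturated chain, a shorter chain, or a terminal amine or carboxylic acid on the chains would address that, and these isomers say nothing about how any such group would read.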